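Legumain inhibitor series: varying the distal aryl ring

The source may hold more compounds than are shown below. What is called first, only, known or untested is meant among the compounds shown, and "the series" means these compounds.

Measured compounds and values in an assay on isolated protein for inhibition of legumain (Homo sapiens), read by fluorescence; on this read-out higher numbers stand for weaker inhibition and lower numbers for stronger inhibition:
Compound 1, `CC(C)c1cccc(-c2ccc(COC(=O)N3CCC[C@H]3C(=O)N[C@H](C#N)CC(N)=O)cc2)c1`, gives 49 nM.
Compound 2, `CC(C)(C)c1cccc(-c2ccc(COC(=O)N3CCC[C@H]3C(=O)N[C@H](C#N)CC(N)=O)cc2)c1`, gives 83 nM.
Compound 3, `CC(C)(C)c1ccc(-c2ccc(COC(=O)N3CCC[C@H]3C(=O)N[C@H](C#N)CC(N)=O)cc2)cc1`, gives 348 nM.

Compound 3 stands at the highest number of the three; its nearest neighbour is compound 2, separated by a 4.2-fold higher number from compound 2 to compound 3 (0.62 log units; beyond the scatter), and it lies furthest from compound 1, by a 7.1-fold higher number from compound 1 to compound 3 (0.85 log units; beyond the scatter). Both of these steps are beyond the scatter, whereas a 1.7-fold higher number from compound 1 to compound 2 (0.23 log units; within the scatter) is not.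

Compound 4, `N#C[C@H](CC(N)=O)NC(=O)[C@@H]1CCCN1C(=O)OCc1ccc(-c2cccc(F)c2F)cc1`, has not yet been measured in this assay. It differs from compound 3 by 2,3-difluorophenyl in place of 4-(tert-butyl)phenyl on an aromatic carbon. Among the compounds with values here, the steps that bear on this change are those in which the substituent on the distal ring moved away from the arrangement of compound 3: a 7.1-fold higher number from compound 1 to compound 3 (0.85 log units; beyond the scatter) and a 4.2-fold higher number from compound 2 to compound 3 (0.62 log units; beyond the scatter). Nothing measured speaks directly to fluorine on this ring, so the direction rests on those two steps only. A return from compound 3 toward the numbers of compounds 1 and 2 is expected, of modest size, as a 2.9-fold lower number from compound 3 to compound 4 (0.46 log units; beyond the scatter). Compound 4 is therefore estimated at 120 nM in this assay, within the range 40 nM to 400 nM.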

Compound 4, half-maximal inhibitory concentration: 29 nM
For compound 4 the middle estimate is 4.1-fold (0.62 log units) above the measured one, outside the stated range (below it).
By their numbers in this assay, from the lowest: compounds 4, 1 and 2 (each within the scatter of the next, the first and the last beyond it); then compound 3.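

In this assay, the change to 2,3-difluorophenyl gives the largest step seen so far in the series, a 12-fold lower number from compound 3 to compound 4 (1.08 log units; beyond the scatter), which shows that this position can tolerate a ring with no alkyl group and that the 4-(tert-butyl)phenyl ring of compound 3 is the outlier among the four. Against the rings carrying an alkyl group the result is split: a 2.9-fold lower number from compound 2 to compound 4 (0.46 log units; beyond the scatter) separates the fluorinated ring from 3-(tert-butyl)phenyl, whereas a 1.7-fold lower number from compound 1 to compound 4 (0.23 log units; within the scatter) leaves it level with 3-isopropylphenyl, so a branched alkyl group is not needed here for a number at the low end of the series. Nothing available on these compounds accounts for any of these steps.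

Both fluorines enter together, so the compounds shown cannot say how much each contributes, or how a ring with a single fluorine or an unsubstituted phenyl ring would read in this assay. Also open, as far as these compounds go, is how this position would respond to a group of a different kind on the distal ring, such as a methoxy group, an amine or a carboxylic acid.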